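The compounds below may be only part of what the source reports. "The series", "measured", "known", "first", "only" and "open" are said of these compounds alone.

Measured compounds, solubility in a physicochemical assay for solubility, with a stated time of 18 h, at pH 7.4; on this read-out lower numbers stand for lower solubility and higher numbers for higher solubility:
- compound 1 `COc1cccc(Oc2ccc3c(NCCCNCc4cc(F)ccc4OC)ccnc3c2)c1` gives 14500 nM
- compound 2 `COc1cccc(Oc2ccc3c(NCCCNCc4cccc(OC)c4O)ccnc3c2)c1` gives 14500 nM
- compound 3 `COc1ccc(F)cc1CNCCCNc1ccnc2cc(Cc3ccccc3)ccc12` gives 4200 nM

Compound 2 stands level with compound 1: no change at the digits printed from compound 1 to compound 2 (within the scatter), so the exchange of the aryl group on the chain carbon bound to the amine nitrogen leaves this assay unmoved. Among the compounds with values here, compound 3 lies below both; the single step there is a 3.5-fold lower number from compound 1 to compound 3 (0.54 log units; beyond the scatter), a modest drop when benzyl replaces 3-methoxyphenoxy on the aromatic carbon of the shared core.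

Compound 4 `COc1cccc(CNCCCNc2ccnc3cc(-c4cccc5ccccc45)ccc23)c1O` is not yet measured. Its difference from compound 2 is naphthalen-1-yl in place of 3-methoxyphenoxy on an aromatic carbon. Within the data shown here, the one step that bears on this is the same aromatic-carbon exchange in compound 1 to compound 3, which gave a 3.5-fold lower number from compound 1 to compound 3 (0.54 log units; beyond the scatter); naphthalen-1-yl is a larger group than benzyl with no hydrogen-bond acceptors, so a drop at least of that size, and possibly somewhat more, is the working expectation. The aryl-chain change from compound 1 to compound 2 does not inform this step.

For compound 4 in this assay the estimate is 3000 nM, range 900 nM to 9000 nM, i.e. an expected step of a 4.8-fold lower number from compound 2 to compound 4 (0.68 log units; beyond the scatter).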

Compound 4, solubility: 32000 nM
Compound 4: the middle estimate sits 11-fold (1.03 log units) below what was measured; measured number outside the range, above it.
By their numbers in this assay, from the lowest: compound 3; then compounds 1 and 2 (each within the scatter of the next); then compound 4.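

In this assay, exchanges at this aromatic carbon do not run in one direction: naphthalen-1-yl in place of 3-methoxyphenoxy gives a 2.2-fold higher number from compound 2 to compound 4 (0.34 log units; beyond the scatter), while benzyl in place of the same group gave a 3.5-fold lower number from compound 1 to compound 3 (0.54 log units; beyond the scatter). Removing 3-methoxyphenoxy, with its 2 hydrogen-bond acceptors, therefore does not by itself bring a lower number, and an entering group with 0 hydrogen-bond acceptors and 2 aromatic rings can stand with a higher one. No measurement shown accounts for the higher number with naphthalen-1-yl.

The two steps at this position start from different aryl groups on the chain, so the compounds shown cannot separate the effect of the entering group from that of its partner, and the absence of change in no change at the digits printed from compound 1 to compound 2 (within the scatter) was seen only with 3-methoxyphenoxy in place. Also open, as far as these compounds go, is how the read-out responds at this aromatic carbon to naphthalen-2-yl, to a simple phenyl, or to a group carrying a carboxylic acid or an amine.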